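Methyl on the amide nitrogen of compound 3

The compounds below may be only part of what the source reports. "The series", "measured", "known", "first", "only" and "open" are said of these compounds alone.

Measured in a physicochemical assay for lipophilicity, measured as octanol-water partition, at pH 7.4; a lower number here means a more polar compound, a higher number a more lipophilic compound:
Compound 1 `Cc1ccc2[nH]c(C(=O)N[C@H]3CN(S(=O)(=O)c4ccccc4)C[C@@H]3C(=O)N[C@H]3CCCNC3)cc2c1`: 1.3
Compound 2 `O=C(N[C@H]1CN(S(=O)(=O)c2ccccc2)C[C@@H]1C(=O)N[C@H]1CCCNC1)c1cc(-c2ccc(Cl)cc2)on1`: 2.1
Compound 3 `O=C(N[C@H]1CN(S(=O)(=O)c2ccccc2)C[C@@H]1C(=O)N[C@H]1CCCNC1)c1cc(-c2ccccc2Cl)on1`: 1.9

Compound 3 sits with the upper pair of the series, the measured steps being a number 0.20 log units lower from compound 2 to compound 3 (within the scatter) and a number 0.60 log units higher from compound 1 to compound 3 (beyond the scatter). Compound 4 `CN(C(=O)[C@H]1CN(S(=O)(=O)c2ccccc2)C[C@@H]1NC(=O)c1cc(-c2ccccc2Cl)on1)[C@H]1CCCNC1` carries one change: methyl in place of hydrogen on an amide-type nitrogen. Within the data shown here, no measured step touches that nitrogen. Among the measured compounds shown here, the measured steps change only groups on a carbonyl carbon or an aromatic carbon, so they offer a size scale and no direct precedent. The largest is a number 0.80 log units higher from compound 1 to compound 2 (beyond the scatter). A small upward move in this assay is expected, the estimated step being a number 0.20 log units higher from compound 3 to compound 4 (within the scatter). Compound 4 is estimated at 2.1, with an expected range of 1.6 to 2.6.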

Compound 4, distribution coefficient: 1.7
For compound 4 the middle estimate is 0.40 log units above the measured one; measured number inside the range.
By their numbers in this assay, from the lowest: compound 1; then compounds 4, 3 and 2 (each within the scatter of the next, the first and the last beyond it).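

Methyl in place of hydrogen on this amide-type nitrogen is the first change shown at this position, and in this assay it gives a number 0.20 log units lower from compound 3 to compound 4 (within the scatter). That step stays within the scatter, so the added methyl leaves compound 4 level with compound 3, whereas the change on the carbonyl carbon gave a number 0.60 log units higher from compound 1 to compound 3 (beyond the scatter). No measurement available here accounts for this result.

On these data alone, whether ethyl or a longer chain ending in an amine on this nitrogen would move the number beyond the scatter stays open. So does the effect of the same methyl on compound 2.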